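A few compounds are considered here, and "the series" means these few. Any claim that something is new, unique, unknown or untested is made for them only; others in the source may bear on it.

Compound 1 `Fc1ccc(-c2nc3cnc(Nc4ccc(C(F)(F)F)cn4)cc3[nH]2)cc1F` and compound 2 `FC(F)(F)c1ccc(Nc2cc3[nH]c(C4CCCC4)nc3cn2)nc1` share one core. In a physicochemical assay for solubility, using the shake flask method, in phosphate buffer, measured as kinetic solubility, with a stated time of 20 h, at pH 6.5 (on this read-out higher numbers stand for higher solubility and lower numbers for lower solubility), compound 1 gives < 5000 nM, which is a limit of the assay rather than a number. Compound 2 gives 145000 nM. The step of an at least 29-fold higher number from compound 1 to compound 2 (1.46 log units; beyond the scatter) is the only measured one, and it concerns a different place on the core. Compound 3 `O=C(O)c1ccc(Nc2cc3[nH]c(-c4ccc(F)c(F)c4)nc3cn2)nc1` differs from compound 1 by carboxy in place of trifluoromethyl on an aromatic carbon. Because compound 1 sits at the limit of < 5000 nM in this assay, at which 1 of the 2 values shown sits, a step upward from it is expected; its size is estimated as an at least 10-fold higher number from compound 1 to compound 3 (1.00 log units; beyond the scatter). Compound 3 is therefore expected to give 50000 nM, between 5000 nM and 300000 nM.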

Compound 3, solubility: 7000 nM
Estimate against measurement, compound 3: 7.1-fold (0.85 log units) above, and the stated range covers the measured number.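

Going by these compounds alone, this is the first measured change at this position, two atoms from the ring nitrogen: carboxy in place of trifluoromethyl gives an at least 1.4-fold higher number from compound 1 to compound 3 (0.14 log units; that floor lies within the scatter) in this assay. Compound 3 has a real number, but compound 1 has only a limit of the assay, so the true step may be larger and a rise beyond the scatter is not established. The step has no upper end because of where compound 1 sits: the limit of < 5000 nM in this assay, at which 1 of the 3 values shown sits.

As far as these compounds go, how an amine or a primary amide would fare at this position stays open. So does whether carboxy would give a similar step alongside the cyclopentyl of compound 2.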